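One Hydroxyl Shift on a Shared Core

The compounds below may be only part of what the source reports. "The series", "measured", "known", "first", "only" and "open" are said of these compounds alone.

Compound 2 `Oc1ccccc1-c1cc(-c2ccccc2O)nc(-c2ccccc2O)c1` gives 2180 nM in a functional assay on HCT-15 cells (Homo sapiens) for cytotoxicity, read by CCK-8 assay, with a stated time of 4 days (a lower number here means a stronger inhibitor, a higher number a weaker inhibitor), the lowest of the two numbers measured there. Compound 1 `Oc1cccc(-c2cc(-c3ccccc3O)nc(-c3ccccc3O)c2)c1` gives 5020 nM in this assay; a 2.3-fold lower number from compound 1 to compound 2 (0.36 log units; beyond the scatter). Compound 3 `Oc1ccc(-c2cc(-c3cccc(O)c3)cc(-c3ccc(O)cc3)n2)cc1` gives only a limit in this assay, > 50000 nM. Compound 4 `Oc1cccc(-c2cc(-c3ccccc3O)cc(-c3ccccc3O)n2)c1` is not yet measured; it differs from compound 2 by 3-hydroxyphenyl in place of 2-hydroxyphenyl on an aromatic carbon. Among the measured compounds shown here, the one measured step that bears on this change is the one between compound 1 and compound 2, which runs the opposite way at a different carbon of the shared core and was modest. A modest rise in the number is therefore expected for compound 4, a 2.1-fold higher number from compound 2 to compound 4 (0.31 log units; beyond the scatter). Compound 4 is expected to give 4500 nM, with a range from 1500 nM to 14000 nM.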

Compound 4, half-maximal inhibitory concentration: 3390 nM
Compound 4: the middle estimate sits 1.3-fold (0.12 log units) above what was measured; the measured number falls inside the stated range.
By their numbers in this assay, from the lowest: compounds 2, 4 and 1 (each within the scatter of the next, the first and the last beyond it). At a limit, above all of these: compound 3.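

At the carbon next to the ring nitrogen, 3-hydroxyphenyl in place of 2-hydroxyphenyl gives a 1.6-fold higher number from compound 2 to compound 4 (0.19 log units; within the scatter) in this assay. At this position, then, the hydroxyl shift leaves no change that can be told from scatter. Among the compounds shown here, the one earlier step involving these two groups, at a different carbon of the shared core, was a 2.3-fold lower number from compound 1 to compound 2 (0.36 log units; beyond the scatter).

The compounds shown leave open how an amine or a carboxylic acid in place of the hydroxyl would read at this position. Compound 3 gives only a limit, and no step to it can be read: the limit of > 50000 nM in this assay, at which 1 of the 4 values shown sits.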